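A few compounds are considered here, and "the series" means these few. Any claim that something is new, unique, unknown or untested is made for them only; others in the source may bear on it.

Working notes on the sulfonamide series. Compound 1 `COc1ccc(S(=O)(=O)Nc2ccc(-c3nc4ccccc4o3)cc2)cc1`, compound 2 `COc1ccccc1S(=O)(=O)Nc1ccc(-c2nc3ccccc3o2)cc1` and compound 3 `O=S(=O)(Nc1ccc(-c2nc3ccccc3o2)cc1)c1ccc(Cl)cc1` have been run in an ADME assay on HEK293 cells (Homo sapiens) for cytotoxicity, read by resazurin assay, with a stated time of 48 h; on this read-out higher numbers stand for lower toxicity in this test and lower numbers for higher toxicity in this test. In this assay compound 1 gives > 100000 nM, which is a limit of the assay and not a number. Compound 2 in this assay likewise reaches only a limit of the assay, > 100000 nM. Compound 3 in this assay also stands at a limit of the assay, > 100000 nM. Since every value sits at the limit of > 100000 nM in this assay, at which 3 of the 3 values shown sit, the steps a step that the two limits leave unreadable from compound 1 to compound 2, a step that the two limits leave unreadable from compound 1 to compound 3 and a step that the two limits leave unreadable from compound 2 to compound 3 cannot be read in size. Compound 4 `Cc1ccc(S(=O)(=O)Nc2ccc(-c3nc4ccccc4o3)cc2)cc1` is not yet measured; it differs from compound 3 by methyl in place of chloro on an aromatic carbon. Within the data shown here, no measured step bears on this change. Because every value shown sits at the limit of > 100000 nM in this assay, at which 3 of the 3 values shown sit, compound 4 is expected at 100000 nM, in the range 30000 nM to 300000 nM, an expected step of a number no higher from compound 3 to compound 4 (the limit leaves the size open) of no size beyond the scatter.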

Compound 4, half-maximal cytotoxic concentration: 88000 nM
The estimate for compound 4 lay 1.1-fold (0.06 log units) above the measured number; the range from low to high includes it.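

In this assay compound 4 gives 88000 nM, and it is the only one shown that gives a number. Compound 1, compound 2 and compound 3 remain at a limit of the assay: the limit of > 100000 nM in this assay, at which 3 of the 4 values shown sit.

With methyl on this aromatic carbon, para to a large group, the series now has an at least 1.1-fold lower number from compound 3 to compound 4 (0.05 log units; that floor lies within the scatter), together with an at least 1.1-fold lower number from compound 2 to compound 4 (0.05 log units; that floor lies within the scatter) and an at least 1.1-fold lower number from compound 1 to compound 4 (0.05 log units; that floor lies within the scatter). Each of these is only a floor, so no change of readable size is established for methyl at this position.

From the compounds shown here alone, the true size of these steps stays open. So does the read-out with an amine or a carboxylic acid on this carbon.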